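A few compounds are considered here, and "the series" means these few. Any claim that something is new, unique, unknown or untested is made for them only; others in the source may bear on it.

Three compounds share one core, a ring-bound imide nitrogen carrying a short side chain and a sulfonamide on the aromatic part. Compound 1 `Cc1ccc(S(=O)(=O)Nc2ccc3c(c2)C(=O)N(Cc2ccc(Cl)cc2)C3=O)cc1` is the starting point; in an assay on isolated protein for inhibition of lysosomal alpha-glucosidase (Rattus norvegicus), read by colorimetric assay (a higher number here means a weaker inhibitor, a lower number a stronger inhibitor), compound 1 gives 188000 nM. Compound 2 `Cc1ccc(S(=O)(=O)Nc2ccc3c(c2)C(=O)N(CCNc2ccccc2)C3=O)cc1` gives 99600 nM, a step of a 1.9-fold lower number from compound 1 to compound 2 (0.28 log units; within the scatter). Compound 3 `Cc1ccc(S(=O)(=O)Nc2ccc3c(c2)C(=O)N(CCOc2cccc(O)c2)C3=O)cc1` gives 55600 nM, which is a 3.4-fold lower number from compound 1 to compound 3 (0.53 log units; beyond the scatter) and, against compound 2, a 1.8-fold lower number from compound 2 to compound 3 (0.25 log units; within the scatter). Compound 3 therefore carries the lowest number of the three, though only its gap to compound 1 is beyond the scatter; compound 2 and compound 3 cannot be told apart.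

Compound 4 `Cc1ccc(S(=O)(=O)Nc2ccc3c(c2)C(=O)N(CCOc2ccc(O)cc2)C3=O)cc1` keeps every atom of compound 3 and moves one hydroxyl: 4-hydroxyphenyl in place of 3-hydroxyphenyl on an oxygen on a saturated carbon. For the measured compounds named here, none of the measured steps touches this kind of change; each of them swaps a whole group on the side chain rather than shifting a substituent around a ring that is already present. The measured steps give no guide to direction, so the expected change is a 1.0-fold lower number from compound 3 to compound 4 (0.00 log units; within the scatter), that is, nothing beyond the scatter. Compound 4 is estimated at 55000 nM, within a range from 20000 nM to 150000 nM.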

Compound 4, half-maximal inhibitory concentration: 47700 nM
Compound 4: middle estimate off by 1.2-fold (0.06 log units), on the high side; the measured number falls inside the stated range.
By their numbers in this assay, from the lowest: compounds 4, 3, 2 and 1 (each within the scatter of the next, the first and the last beyond it).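

Moving the hydroxyl around a ring already in place is a new kind of change in this series: in this assay, 4-hydroxyphenyl in place of 3-hydroxyphenyl on the oxygen gives a 1.2-fold lower number from compound 3 to compound 4 (0.07 log units; within the scatter), so this assay cannot distinguish the two hydroxyl placements. Swapping anilino for 4-hydroxyphenoxy gives a 2.1-fold lower number from compound 2 to compound 4 (0.32 log units; beyond the scatter), a modest step beyond the scatter where the swap to 3-hydroxyphenoxy stayed within it, but that contrast is thin since compound 3 and compound 4 cannot be told apart, while (4-hydroxyphenoxy)methyl in place of 4-chlorophenyl gives a 3.9-fold lower number from compound 1 to compound 4 (0.60 log units; beyond the scatter), a modest step that agrees with what compound 3 showed. Nothing available explains any of these steps.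

As far as these compounds go, it remains open whether a plain phenoxy group with no hydroxyl, a methoxy group in the hydroxyl's place, or a longer chain between the amide-type nitrogen and the oxygen would change the number. From the compounds shown here alone, all four compounds also keep the sulfonamide of the shared core, so the effect of an amine or a carboxylic acid there is unknown.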